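Cytotoxicity notes on a phenoxy-to-carboxymethyl exchange

The source may hold more compounds than are shown below. What is called first, only, known or untested is meant among the compounds shown, and "the series" means these compounds.

Measured so far:
Compound 1 `CC(C)N(Cc1cccc(OCCCCCC(=O)O)c1)C(=O)c1ccc(-c2cccc(Oc3ccccc3)c2)cc1` gives in an ADME assay on BJ cells (Homo sapiens) for cytotoxicity, read by CellTiter-Glo and resazurin assay, with a stated time of 72 h (on this read-out higher numbers stand for an effect only at larger amounts of compound and lower numbers for an effect already at smaller amounts), only a limit of the assay, > 18700 nM.
Compound 2 `CCOC(=O)CCCCCOc1cccc(CN(C(=O)c2ccc(-c3cccc(Oc4ccccc4)c3)cc2)C(C)C)c1` gives in this assay only a limit of the assay, > 19600 nM.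

Compound 2 stands at the limit of > 19600 nM in this assay, at which 1 of the 2 values shown sits, which is a limit and not a number. Compound 1 sits at the limit of > 18700 nM in this assay, at which 1 of the 2 values shown sits. With both values limits, a step that the two limits leave unreadable from compound 1 to compound 2 cannot be read. Compound 3 `CCOC(=O)CCCCCOc1cccc(CN(C(=O)c2ccc(-c3cccc(CC(=O)O)c3)cc2)C(C)C)c1` differs from compound 2 by carboxymethyl in place of phenoxy on an aromatic carbon. Among the measured compounds shown here, no measured step covers this change, so nothing points to a readable shift in this assay beyond the scatter. Compound 3 is expected to sit again at a limit, estimated at 20000 nM with a range of 10000 nM to 40000 nM. The expected step is a step that the limit leaves unreadable from compound 2 to compound 3.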

Compound 3, half-maximal effective concentration: > 26000 nM
Compound 3: only a limit was reported; the forecaster's own chance of this, stated with the estimate: 85%; middle value at least 1.3-fold (0.11 log units) away from the limit.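

Compound 3 gives > 26000 nM in this assay, a limit of the assay. Compound 2 gives > 19600 nM, also a limit, so the step between compound 2 and compound 3 cannot be read. The concentration at which any compound shown reaches a half-maximal effect remains open.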